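Swapping chloro for two fluoro groups at the amide

A few compounds are considered here, and "the series" means these few. Any claim that something is new, unique, unknown or untested is made for them only; others in the source may bear on it.

Compound 1, `COc1ccc(NC(=O)c2nnc(COc3ccc(CCC(=O)O)cc3)s2)cc1`: in a functional assay on CHO cells for agonist activity at Free fatty acid receptor 1 (Homo sapiens), read by calcium flux (on this read-out lower numbers stand for an effect already at smaller amounts and higher numbers for an effect only at larger amounts of compound), compound 1 gives > 10000 nM, which is a limit of the assay and not a number.
Compound 2, `O=C(O)CCc1ccc(OCc2nnc(C(=O)Nc3ccc(F)cc3)s2)cc1`: compound 2 gives 6640 nM.
Compound 3, `O=C(O)CCc1ccc(OCc2nnc(C(=O)Nc3ccc(Cl)cc3)s2)cc1`: compound 3 gives 3690 nM.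

Of the two numbers that were obtained, compound 3 has the lower one, and its nearest neighbour is compound 2, with a 1.8-fold lower number from compound 2 to compound 3 (0.26 log units; within the scatter). Compound 1 sits at the limit of > 10000 nM in this assay, at which 1 of the 3 values shown sits. Compound 4, `O=C(O)CCc1ccc(OCc2nnc(C(=O)Nc3ccc(F)c(F)c3)s2)cc1`, differs from compound 3 in one place: 3,4-difluorophenyl in place of 4-chlorophenyl on an amide-type nitrogen. Among the compounds with values here, three measured steps touch this same ring. Going from methoxy to a halogen gave an at least 1.5-fold lower number from compound 1 to compound 2 (0.17 log units; that floor lies within the scatter) and an at least 2.7-fold lower number from compound 1 to compound 3 (0.43 log units; beyond the scatter), while exchanging one halogen for the other gave a 1.8-fold lower number from compound 2 to compound 3 (0.26 log units; within the scatter). Compound 4 keeps halogens on this ring, so the change from compound 3 is expected to be small; the estimated step is a 1.2-fold higher number from compound 3 to compound 4 (0.09 log units; within the scatter), with no shift beyond the scatter foreseen. Compound 4 is therefore expected to give about 4500 nM in this assay, most likely between 1500 nM and 14000 nM, with some chance that only a limit is reported.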

Compound 4, half-maximal effective concentration: 580 nM
For compound 4 the middle estimate is 7.8-fold (0.89 log units) above the measured one; measured number outside the range, below it.
By their numbers in this assay, from the lowest: compound 4; then compounds 3 and 2 (each within the scatter of the next). At a limit, above all of these: compound 1.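

The ring on the amide nitrogen proves far more sensitive than the earlier halogen exchange suggested: adding one fluoro gives an 11-fold lower number from compound 2 to compound 4 (1.06 log units; beyond the scatter), and 3,4-difluorophenyl in place of 4-chlorophenyl gives a 6.4-fold lower number from compound 3 to compound 4 (0.80 log units; beyond the scatter). Among these compounds, adding a second halogen to the ring does what exchanging one halogen for another did not, as that exchange gave only a 1.8-fold lower number from compound 2 to compound 3 (0.26 log units; within the scatter). Against 4-methoxyphenyl the gain reaches an at least 17-fold lower number from compound 1 to compound 4 (1.23 log units; beyond the scatter), which is only a floor, since the starting value is a limit of the assay: the limit of > 10000 nM in this assay, at which 1 of the 4 values shown sits.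

The compounds shown leave open whether both fluoro groups are needed for this gain. They also leave open whether a second chloro, a trifluoromethyl or a nitrile on this ring would serve as well.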